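A few compounds are considered here, and "the series" means these few. Any claim that something is new, unique, unknown or untested is made for them only; others in the source may bear on it.

Working notes on the series. Compound 1 `COc1ccc(-c2cc(-c3ccc(S(=O)(=O)NC4CC4)cc3)cnc2N)cn1` gives in an in vitro ADME assay on microsomes from liver (Homo sapiens) for metabolic stability (on this read-out higher numbers stand for fast clearance and lower numbers for slow clearance), a value of 15 mL.min-1.g-1. Compound 2 `COc1ccc(-c2cc(-c3ccc(NS(C)(=O)=O)cc3)cnc2N)cn1` is reported in this assay only as a limit, < 7 mL.min-1.g-1, so its exact clearance is not known. Within the data shown here, the single measured step, an at least 2.1-fold lower number from compound 1 to compound 2 (0.33 log units; beyond the scatter), therefore runs from a number down to a limit; its true size is open, and the evidence is only (the limit of < 7 mL.min-1.g-1 in this assay, at which 1 of the 2 values shown sits).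

Compound 3 `COc1ccc(-c2cc(-c3ccc(C(=O)O)cc3)cnc2N)cn1` is not yet measured in this assay. It differs from compound 2 by carboxy in place of methanesulfonamido on an aromatic carbon. Among the measured compounds shown here, no measured step bears directly on this exchange: the one step in hand swaps one sulfur-bearing group for another at the same place and says nothing about a carboxy. What the series shows is that both measured compounds clear slowly, with compound 2 at the lower limit of the assay. Starting from a compound already at the limit, the most that can be expected is a position near that limit, with a fair chance of another limit rather than a number.

Compound 3 is expected to give about 7 mL.min-1.g-1, within a range of 3 mL.min-1.g-1 to 15 mL.min-1.g-1. The expected step is thus a number no lower from compound 2 to compound 3 (the limit leaves the size open).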

Compound 3, intrinsic clearance in microsomes: < 7 mL.min-1.g-1
Compound 3 was reported as a limit; the forecaster's own chance of this, stated with the estimate: 55%; the middle value lies on the limit itself.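

Carboxy in place of cyclopropylsulfamoyl gives in this assay an at least 2.1-fold lower number from compound 1 to compound 3 (0.33 log units; beyond the scatter), so at this position a reading this low is no longer confined to a sulfur-bearing group, and compound 1, with cyclopropylsulfamoyl, remains the only compound shown that gives a number. Compound 3 stands only as a limit, < 7 mL.min-1.g-1, so the true size of this step is open. The exchange of methanesulfonamido for carboxy cannot be read, and no order can be given for compound 2 and compound 3, because both stand as limits: the limit of < 7 mL.min-1.g-1 in this assay, at which 2 of the 3 values shown sit.

The compounds shown leave open how much clearance remains in compound 2 and compound 3, and whether the two differ at all, since neither has a number in this assay. They also leave open which part of the cyclopropylsulfamoyl group goes with the higher number of compound 1, and whether an unsubstituted sulfamoyl, a primary carboxamide or an amine at this position would give a number or another limit.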